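The source may report more compounds than this note shows. Statements on the series, on what has been measured and on what is new or still open speak of the compounds shown alone.

In a functional assay on HeLa cells (Homo sapiens) for inhibition, read by CCK-8 assay, with a stated time of 72 h, tested at 2 uM (a higher number here means more inhibition of growth at the concentration tested, a lower number less inhibition of growth), compound 1 (`COc1ccc(SCc2ccc(/C=C/C(=O)Nc3ccccc3N)cc2)cc1OC`) gives 10.1% and compound 2 (`Nc1ccccc1NC(=O)/C=C/c1ccc(CSc2ccc(C(F)(F)F)cn2)cc1`) gives 6.07%. These two numbers lie within the usual scatter of each other, so the data do not separate compound 2 from compound 1. The next compound to be tested is compound 3 (`Cc1ccc(SCc2ccc(/C=C/C(=O)Nc3ccccc3N)cc2)cc1`), which carries 4-methylphenyl in place of 5-(trifluoromethyl)pyridin-2-yl on a sulfur. Among the measured compounds shown here, only one measured step bears on this change, a swap of the group on the same sulfur, and it is small: a number 4 percentage points lower from compound 1 to compound 2 (within the scatter). For the measured compounds named here, with only this step as a guide, no change beyond the scatter is expected in this assay. The expected step is a number 2.9 percentage points higher from compound 2 to compound 3 (within the scatter). For compound 3 the estimated value is 9%, with an expected range from 2% to 22%.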

Compound 3, percent growth inhibition at one concentration: 25.5%
Beside the measured number, compound 3's estimate is 16.5 percentage points below it, outside the stated range (above it).
By their numbers in this assay, from the lowest: compounds 2 and 1 (each within the scatter of the next); then compound 3.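

Among the compounds shown here, on the sulfur, the group can shift the result in this assay: 4-methylphenyl in place of 5-(trifluoromethyl)pyridin-2-yl gives a number 19.4 percentage points higher from compound 2 to compound 3 (beyond the scatter) whereas the one earlier swap at this place stayed within the scatter. Putting 4-methylphenyl in place of 3,4-dimethoxyphenyl gives a number 15.4 percentage points higher from compound 1 to compound 3 (beyond the scatter) as well, so compound 3 stands apart from two compounds that cannot be told apart from each other. No measurement shown here explains this difference.

On these data alone, what remains open is whether the methyl group itself matters or whether the plain carbon ring is enough, a question that an unsubstituted phenyl on the same sulfur would address. As far as these compounds go, it is also open whether a 4-ethylphenyl or a 4-aminophenyl group would move the number further in either direction.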